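The source may hold more compounds than are shown below. What is called first, only, known or untested is meant among the compounds shown, and "the series" means these compounds.

Measured compounds, with their numbers in an assay on cells for inhibition of high affinity 3',5'-cyclic-AMP phosphodiesterase 7A (Homo sapiens), read by scintillation counting and cAMP accumulation, with a stated time of 30 min; a lower number here means a stronger inhibitor, a higher number a weaker inhibitor:

Compound 1 `CCn1c(NC(C)C)nc2c(C3CCN(c4ccccn4)CC3)csc2c1=O` gives 6.8 nM.
Compound 2 `CCn1c(N[C@H]2CC[C@H](C(=O)OC)CC2)nc2ccsc2c1=O` gives 2100 nM.
Compound 3 `CCn1c(CC(C)C)nc2ccsc2c1=O` gives 4700 nM.

Compound 3 stands at the highest number of the three, so it is the weakest inhibitor of the set, and both of its gaps to the others lie beyond the scatter. Its nearest neighbour is compound 2, whose number is lower, and the gap to compound 1 is wide. Compounds 1 and 2 both carry an amino substituent on the aromatic carbon between the two ring nitrogen atoms; compound 3 carries an isobutyl there instead.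

Compound 4 `CCCNc1nc2ccsc2c(=O)n1CC` is not yet measured. It differs from compound 3 in one place: propylamino in place of isobutyl on an aromatic carbon. Apart from that, the core of compound 3 is kept unchanged, with no further substituent added.

For the measured compounds named here, no step between measured compounds isolates this change. Compound 2, with an amino group in that place, gives 2100 nM, a lower number than compound 3, though its amino group is a different one. The expectation for compound 4 is therefore a modest step towards a lower number, a 1.9-fold lower number from compound 3 to compound 4 (0.27 log units; within the scatter), with the possibility that it stays within the scatter of compound 3. The estimate for compound 4 in this assay is 2500 nM, with a range from 600 nM to 10000 nM.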

Compound 4, half-maximal inhibitory concentration: 1400 nM
For compound 4 the middle estimate is 1.8-fold (0.25 log units) above the measured one; the range from low to high includes it.
By their numbers in this assay, from the lowest: compound 1; then compounds 4 and 2 (each within the scatter of the next); then compound 3.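

In this assay, propylamino in place of isobutyl on the aromatic carbon between two ring nitrogen atoms gives a 3.4-fold lower number from compound 3 to compound 4 (0.53 log units; beyond the scatter), a step beyond the scatter and the first in the series that isolates this position, with the rest of the core kept unchanged. The two groups have the same heavy-atom count, so the step goes with replacing one carbon by nitrogen and with the hydrogen-bond donor and acceptor counted for propylamino, not with a change in the number of heavy atoms; this holds for this one pair only. No measurement shown here gives the reason for the step.

From the compounds shown here alone, it remains open whether the step depends on the nitrogen atom itself or on its hydrogen, which a propoxy or methyl(propyl)amino group on the same carbon would help to separate. Compound 1 differs from compound 4 in more than one place, so the compounds shown also leave open how much of the value of compound 1, 6.8 nM, belongs to any single change.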